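Three close values and one untested fluorophenyl swap

A few compounds are considered here, and "the series" means these few. Any claim that something is new, unique, unknown or untested is made for them only; others in the source may bear on it.

- compound 1 `COC(=O)/C(=C/c1ccccc1)CN1C(=O)[C@@H](OC)[C@H]1c1ccc(Cl)cc1`: 15600 nM
- compound 2 `COC(=O)/C(=C/c1ccccc1)CN1C(=O)[C@@H](OC)[C@H]1c1ccc(F)cc1`: 21800 nM
- compound 3 `COC(=O)/C(=C/c1ccccc1)CN1C(=O)[C@@H](OC)[C@H]1c1ccc(Cl)cc1Cl`: 19000 nM

These three compounds were tested in a functional assay on MDA-MB-231 cells (Homo sapiens) for antiproliferative activity, read by MTT assay, with a stated time of 48 h; a lower number here means a stronger inhibitor, a higher number a weaker inhibitor. They share one core and differ only in the halogens on one phenyl group. Compound 3 lies within the usual scatter of both other compounds, so the three values cannot be placed in a meaningful order.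

The next compound is compound 4 `COC(=O)/C(=C/c1ccccc1)CN1C(=O)[C@@H](OC)[C@H]1c1cccc(F)c1`, which has not yet been measured. Its change from the previous compound is 3-fluorophenyl in place of 2,4-dichlorophenyl on a saturated ring carbon. The closest guide is a 1.1-fold lower number from compound 2 to compound 3 (0.06 log units; within the scatter), which has 2,4-dichlorophenyl in place of 4-fluorophenyl. Two more steps also bear on it: a 1.4-fold higher number from compound 1 to compound 2 (0.15 log units; within the scatter), with fluoro in place of chloro, and a 1.2-fold higher number from compound 1 to compound 3 (0.09 log units; within the scatter), with chloro in place of hydrogen. All three steps are small. Among the measured compounds shown here, no measured compound carries a 3-fluorophenyl group, which leaves this particular group untested.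

No step beyond the scatter is therefore expected in this assay. The expected step is a 1.1-fold higher number from compound 3 to compound 4 (0.02 log units; within the scatter). The estimated value for compound 4 is 20000 nM, with an expected range of 10000 nM to 40000 nM.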

Compound 4, half-maximal inhibitory concentration: 34400 nM
Compound 4: middle estimate off by 1.7-fold (0.24 log units), on the low side; the measured number falls inside the stated range.
By their numbers in this assay, from the lowest: compounds 1, 3, 2 and 4 (each within the scatter of the next, the first and the last beyond it).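

In this assay, the change at this saturated ring carbon gives the first step among these compounds that clears the scatter: a 2.2-fold higher number from compound 1 to compound 4 (0.34 log units; beyond the scatter), with 3-fluorophenyl in place of 4-chlorophenyl. The other two new steps, a 1.8-fold higher number from compound 3 to compound 4 (0.26 log units; within the scatter) and a 1.6-fold higher number from compound 2 to compound 4 (0.20 log units; within the scatter), stay within the scatter, so compound 4 cannot be separated from compound 2 or compound 3, and swapping 4-fluorophenyl for 3-fluorophenyl gives no clear difference on its own. Among the compounds shown here, the position therefore shows only a modest spread across the four groups tested, with compound 1 and compound 4 the one separated pair, and no evidence is available to explain that gap.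

Every compound shown carries a phenyl group with at least one halogen at this carbon, so it remains open how plain phenyl, 3-chlorophenyl or a phenyl group bearing an amine or a carboxylic acid would compare. The methyl ester, the methoxy group and the other phenyl group are the same throughout, so these four compounds say nothing about how much those parts of the shared core matter.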